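The source may hold more compounds than are shown below. What is called first, only, known or untested is meant among the compounds shown, and "the series" means these compounds.

Working notes on the series in an ADME assay on liver (Macaca fascicularis) for metabolic stability, using microsomes, with a stated time of 10 min, tested at 0.5 uM; a higher number here means that more of the compound is left, a lower number that less of the compound is left

Compound 1 `Cc1ccncc1-c1cccc2c1cnn2-c1nccs1` - "not determined" (no result reported)
Compound 2 `Cc1ccncc1-c1cccc2c1ncn2-c1cnccn1` - 83%

In this assay, among the compounds with values here, compound 2 gives 83% and this is the only number so far, so it cannot yet be ranked against anything. Compound 1 carries no number ("not determined" (no result reported)).

Compound 3 `Cc1ccncc1-c1cccc2c1ncn2-c1cscn1` is still to be measured. It differs from compound 2 by 1,3-thiazol-4-yl in place of pyrazin-2-yl on an aromatic nitrogen. Within the data shown here, no measured pair shows what such a change does, so the expectation is loose. Compound 2 at 83% has little room left to rise, so in this assay a modest fall is expected, possibly none beyond the scatter. The estimated move is a number 9 percentage points lower from compound 2 to compound 3 (within the scatter) (a wide expectation). For compound 3 the estimated value is 74% (expected range 52% to 90%).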

Compound 3, percent of the compound remaining: 50%
For compound 3 the middle estimate is 24 percentage points above the measured one, outside the stated range (below it).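

Within the data shown here, the group on the aromatic nitrogen of the five-membered aromatic ring is not a neutral place in this assay: 1,3-thiazol-4-yl in place of pyrazin-2-yl gives a number 33 percentage points lower from compound 2 to compound 3 (beyond the scatter), the first reading of any change at this position. The two groups have the same counts of hydrogen-bond donors and acceptors and no net charge, so those counts do not separate compound 2 from compound 3; they differ in ring size and in the sulfur of the 1,3-thiazol-4-yl group. Nothing available bears on the reason for this step.

Among these compounds, with only this one pair, it remains open whether ring size or the sulfur accounts for the step. Also open, going by these compounds, is where a phenyl or a pyridin-2-yl group on the same nitrogen would fall relative to compound 2 and compound 3.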